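Epimer of compound 2 at one saturated ring carbon

A few compounds are considered here, and "the series" means these few. Any claim that something is new, unique, unknown or untested is made for them only; others in the source may bear on it.

Compound 1 `Cc1nsc2c1ncn2[C@H]1C[C@H](O)[C@@H](CO)O1` and compound 2 `Cc1nsc2c1ncn2[C@@H]1O[C@H](CO)[C@@H](O)[C@@H]1O` share a common core. In a functional assay on L1210 cells (Mus musculus) for antiproliferative activity (on this read-out higher numbers stand for weaker inhibition and lower numbers for stronger inhibition), compound 1 reaches only the assay limit, > 100000 nM. Compound 2 likewise shows only a limit in this assay, > 100000 nM. Among the compounds with values here, the one measured step, hydroxy in place of hydrogen on a saturated ring carbon, is a step that the two limits leave unreadable from compound 1 to compound 2; both ends rest on (the limit of > 100000 nM in this assay, at which 2 of the 2 values shown sit), so no size can be read from it. Compound 3 `Cc1nsc2c1ncn2[C@@H]1O[C@H](CO)[C@@H](O)[C@H]1O` differs from compound 2 only in configuration: the two compounds have the same atoms and bonds and differ only in configuration as drawn: 1 of 4 stereo elements differ; a stereocentre at a saturated ring carbon is drawn S in compound 2 and R in compound 3. The expected step is a number no higher from compound 2 to compound 3 (the limit leaves the size open), nothing beyond the scatter. Compound 3 is estimated at 100000 nM, range 50000 nM to 300000 nM.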

Compound 3, half-maximal inhibitory concentration: 10000 nM
Compound 3: middle estimate off by 10-fold (1.00 log units), on the high side; measured number below the stated range.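

In this assay, this stereocentre matters: changing its drawn configuration from S to R gives an at least 10-fold lower number from compound 2 to compound 3 (1.00 log units; beyond the scatter). Hydroxy in place of hydrogen on a saturated ring carbon gives an at least 10-fold lower number from compound 1 to compound 3 (1.00 log units; beyond the scatter) when drawn R. The same kind of change with S drawn, from compound 1 to compound 2, cannot be read because both ends are limits: the limit of > 100000 nM in this assay, at which 2 of the 3 values shown sit.

The compounds shown leave open whether an amine or a fluorine at this carbon would keep the activity of compound 3. From the compounds shown here alone, how far the number falls from compound 2 also stays open, since its value is only a limit.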